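Azepanyl urea on the azetidine amide core: expected outcome

A few compounds are considered here, and "the series" means these few. Any claim that something is new, unique, unknown or untested is made for them only; others in the source may bear on it.

The shared core is carried by compound 1 `O=C(c1ccc(Cl)cc1)N1CC(c2nc(-c3cccc(F)c3)no2)C1`, compound 2 `O=C(C1CCC(F)(F)CC1)N1CC(c2nc(-c3cccc(F)c3)no2)C1` and compound 3 `CC1CCCC(C(=O)N2CC(c3nc(-c4cccc(Cl)c4)no3)C2)C1`. In an assay on HEK293 cells for negative allosteric modulation of metabotropic glutamate receptor 5 (Homo sapiens), read by FLIPR (on this read-out lower numbers stand for stronger inhibition and higher numbers for weaker inhibition), compound 1 gives only a limit, > 10000 nM. Compound 2 likewise gives only a limit, > 10000 nM. Compound 3 also gives only a limit, > 10000 nM, so it stands at the edge of what this assay reports, no better and no worse than the others can be read. Within the data shown here, the one step with both ends measured, a step that the two limits leave unreadable from compound 1 to compound 2, cannot be sized because both ends sit at the limit (the limit of > 10000 nM in this assay, at which 3 of the 3 values shown sit).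

Compound 4 `O=C(N1CCCCCC1)N1CC(c2nc(-c3cccc(Cl)c3)no2)C1` differs from compound 3 by azepan-1-yl in place of 3-methylcyclohexyl on a carbonyl carbon. Among the measured compounds shown here, no measured step bears directly on this change, and every value shown sits at the limit (the limit of > 10000 nM in this assay, at which 3 of the 3 values shown sit), so no direction is readable from the data. Compound 4 is therefore expected to remain at or near the limit, with the step that the limit leaves unreadable from compound 3 to compound 4 expected to be none beyond the scatter. The estimate for compound 4 is 15000 nM, in a range from 4000 nM to 50000 nM.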

Compound 4, half-maximal inhibitory concentration: > 10000 nM
Compound 4: no number, only a limit (the forecaster's own chance of this, stated with the estimate: 75%); the middle value does not contradict the limit.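

In this assay compound 4 gives > 10000 nM, a limit and not a number. Among these compounds, no step from compound 3 to compound 4 can be read. The compounds shown leave open whether any group on the carbonyl carbon of the shared core gives a number rather than a limit.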